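Moving a Methoxy Group on a Sulfonate Ester

This account rests on a few compounds, and the source may have more. Where it says the series, first, only, none or still open, it means among the compounds named here.

Compound 1: `COc1cccc(OS(=O)(=O)c2ccc(N3CCN(C)C3=O)cc2)c1`, 1600 nM
Compound 2: `CCCCN1CCN(c2ccc(S(=O)(=O)Oc3cccc(OC)c3)cc2)C1=O`, 30000 nM

In a functional assay on M21 cells (Homo sapiens) for antiproliferative activity, read by sulforhodamine B assay, with a stated time of 48 h (a higher number here means a weaker inhibitor, a lower number a stronger inhibitor), compound 1 gives 1600 nM and compound 2 gives 30000 nM. Compound 2 has the higher of the two numbers, making it the weaker inhibitor, as the step of a 19-fold higher number from compound 1 to compound 2 (1.27 log units; beyond the scatter) shows. Among the compounds with values here, compound 3 is `CCCCN1CCN(c2ccc(S(=O)(=O)Oc3ccc(OC)cc3)cc2)C1=O`. 4-methoxyphenyl in place of 3-methoxyphenyl on an oxygen The only measured step concerns the chain on the ring nitrogen, not the methoxyphenyl group, and no measured step bears on this change. The step of no change at the digits printed from compound 2 to compound 3 (within the scatter) is estimated to stay within the scatter, in either direction. Compound 3 is expected to give about 30000 nM, between 8000 nM and 100000 nM.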

Compound 3, half-maximal inhibitory concentration: > 100000 nM
Compound 3: a limit, no number; the forecaster's own chance of this, stated with the estimate: 25%; middle value at least 3.3-fold (0.52 log units) from the limit.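

Until now only the chain on the ring nitrogen had varied; this pair shows that the methoxyphenyl group on the sulfonate oxygen matters as well. In this assay, exchanging 3-methoxyphenyl for 4-methoxyphenyl, with the same atoms joined differently, gives an at least 3.3-fold higher number from compound 2 to compound 3 (0.52 log units; beyond the scatter). Compound 3 reads > 100000 nM, which is a limit of the assay and not a number, so the full size of this step stays unknown: the limit of > 100000 nM in this assay, at which 1 of the 3 values shown sits.

Still open, on these data alone, is whether 4-methoxyphenyl costs as much alongside the ring-nitrogen group of compound 1. Also open, as far as these compounds go, is how a hydroxyl or an amine in place of the methoxy group would read.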